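Swapping the Aryl Group on a Dicarboxylic Acid Core

The source may hold more compounds than are shown below. What is called first, only, known or untested is meant among the compounds shown, and "the series" means these compounds.

Compound 2 `Cc1ccc(-c2cc3cc(C(=O)O)c(C(=O)O)cc3n2O)cc1` carries two carboxylic acids on the shared core. In an assay on isolated protein for inhibition of Amine oxidase [flavin-containing] A (Homo sapiens), read by fluorescence and spectrophotometry, with a stated time of 20 min (on this read-out lower numbers stand for stronger inhibition and higher numbers for weaker inhibition), compound 2 reaches only > 100000 nM, a limit of the assay rather than a number, and so it stands at the limit of > 100000 nM in this assay, at which 1 of the 2 values shown sits. Compound 1 `N#Cc1cc2cc(-c3cccs3)n(O)c2cc1C#N`, with a thiophene and two nitriles, gives 11100 nM in this assay. Compound 3 `O=C(O)c1cc2cc(-c3cccs3)n(O)c2cc1C(=O)O` comes from compound 2 by thiophen-2-yl in place of 4-methylphenyl on an aromatic carbon. Among the measured compounds shown here, with no measured step of this kind to lean on, the expected step of an at least 1.2-fold lower number from compound 2 to compound 3 (0.09 log units; that floor lies within the scatter) is small, if any. Compound 3 is therefore estimated at 80000 nM, within 20000 nM to 300000 nM, with a fair chance that only a limit is reported again.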

Compound 3, half-maximal inhibitory concentration: > 100000 nM
Compound 3: a limit, no number; the forecaster's own chance of this, stated with the estimate: 60%; middle value at least 1.2-fold (0.09 log units) away from the limit.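

Compound 2 and compound 3 both end at a limit of this assay rather than a number, so no step can be read between them: the limit of > 100000 nM in this assay, at which 2 of the 3 values shown sit.

From the compounds shown here alone, whether thiophen-2-yl in place of 4-methylphenyl changes inhibition at all on this shared core stays open.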